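This account rests on a few compounds, and the source may have more. Where it says the series, first, only, none or still open, it means among the compounds named here.

Measured compounds:
compound 1, `Oc1ccc(-c2cc(-c3cccc(F)c3)cc(-c3cccc(O)c3)n2)cc1`: 2700 nM
compound 2, `Oc1cccc(-c2cc(-c3ccc(C(F)(F)F)cc3)cc(-c3cccc(O)c3)n2)c1`: 33500 nM

In a functional assay on DU-145 cells (Homo sapiens) for inhibition (a lower number here means a stronger inhibitor, a higher number a weaker inhibitor), compound 2 gives 33500 nM and stands as the higher of the two numbers in hand; compound 1, with 2700 nM, sits far lower, and the gap between the two lies beyond the scatter of the method. Compound 1 and compound 2 differ in two places, so only the two values themselves can be read from that pair.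

Compound 3, `Oc1ccc(-c2cc(-c3ccc(C(F)(F)F)cc3)cc(-c3cccc(O)c3)n2)cc1`, is the next compound to be measured in this assay. It differs from compound 2 in one place: 4-hydroxyphenyl in place of 3-hydroxyphenyl on an aromatic carbon. The two hydroxyphenyl groups of compound 3 now match those of compound 1, which gives 2700 nM, while the trifluoromethylphenyl group of compound 2 is kept. The expected step of a 2.8-fold lower number from compound 2 to compound 3 (0.45 log units; beyond the scatter) points toward a lower number, but short of what compound 1 shows. Compound 3 is estimated at 12000 nM, between 4000 nM and 40000 nM.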

Compound 3, half-maximal inhibitory concentration: > 50000 nM
Compound 3 was reported as a limit; the forecaster's own chance of this, stated with the estimate: 5%; middle value at least 4.1-fold (0.61 log units) from the limit.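

Compound 3 is reported only as a limit: the limit of > 50000 nM in this assay, at which 1 of the 3 values shown sits.

In this assay the change of hydroxyphenyl group gives an at least 1.4-fold higher number from compound 2 to compound 3 (0.17 log units; that floor lies within the scatter) and, with that floor, shows no gain from 4-hydroxyphenyl in place of 3-hydroxyphenyl when the 4-(trifluoromethyl)phenyl group is kept. For the compounds shown here, the other change gives an at least 18-fold higher number from compound 1 to compound 3 (1.26 log units; beyond the scatter) and is the first single-place comparison to show that the aryl group at this position can carry a large share of the inhibition, with both hydroxyphenyl groups held constant.

The compounds shown leave open whether the swap between the two hydroxyphenyl groups changes the number at all, since the true size of that step is hidden by the limit. They also leave open how an amine or a carboxylic acid would read on the aryl group in place of the trifluoromethyl.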